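The source may report more compounds than this note shows. Statements on the series, on what has been measured and on what is new or still open speak of the compounds shown alone.

Measured in a toxicity assay on NIH3T3 cells (Mus musculus) for cytotoxicity, read by resazurin assay; a higher number here means that more compound is needed for the effect, a lower number that less compound is needed:
- Compound 1 `COC(=O)c1ccc(NCc2cncn2Cc2ccccc2)cc1-c1ccccc1`: > 1000 nM
- Compound 2 `c1ccc(Cn2cncc2CNc2cccc(-c3ccncc3)c2)cc1`: > 1000 nM
- Compound 3 `Cc1ccccc1-c1cccc(NCc2cncn2Cc2ccccc2)c1`: > 1000 nM

Each of these entries is a limit of the assay and not a number. Compound 3 therefore has no exact place in the series, and its result of > 1000 nM is known only as a limit.

Compound 4 `c1ccc(Cn2cncc2CNc2cccc(-c3ccccc3)c2)cc1` differs from compound 3 by one change, hydrogen in place of methyl on an aromatic carbon, ortho to a large group, so that 2-methylphenyl becomes phenyl: hydrogen in place of methyl on an aromatic carbon.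

Within the data shown here, the only measured step that bears on this group is a step that the two limits leave unreadable from compound 2 to compound 3. It gives no size that could be carried over to the new change. No step beyond the usual scatter is therefore expected in this assay, and no direction can be favoured. Compound 4 is expected to report a limit as well, because of the limit of > 1000 nM in this assay, at which 3 of the 3 values shown sit. The step expected on this reading is a step that the limit leaves unreadable from compound 3 to compound 4. Should a number be reported, the estimated value for compound 4 is 2000 nM, with an expected range from 1000 nM to 10000 nM.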

Compound 4, half-maximal effective concentration: > 750 nM
Compound 4 ended at the assay's limit (the forecaster's own chance of this, stated with the estimate: 85%); the middle value lies beyond the limit too.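

Compound 4 gives > 750 nM, which is a limit of the assay and not a number. Among these compounds, compound 1, compound 2 and compound 3 also stand at limits, and no step from any of them to compound 4 can be read. The compounds shown leave open at what concentration any of them reaches the half-maximal effect in this assay.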